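Replacing a piperazinylethyl chain with a methylsulfonylphenyl ring

A few compounds are considered here, and "the series" means these few. Any claim that something is new, unique, unknown or untested is made for them only; others in the source may bear on it.

Compound 1 `CNc1nc(NCCN2CCNCC2)c2sc(-c3ccc(C(F)(F)F)cc3)cc2n1` gives 203 ug/mL in a physicochemical assay for solubility, at pH 2 (a lower number here means a less soluble compound, a higher number a more soluble compound), the highest of the two numbers measured. Compound 2 `CNc1nc(Nc2cccc(C(N)=O)c2)c2sc(-c3ccc(C(F)(F)F)cc3)cc2n1` gives 85 ug/mL in the same assay, and the step of a 2.4-fold lower number from compound 1 to compound 2 (0.38 log units; beyond the scatter) shows what exchanging the chain for an aryl amide brings. Compound 3 `CNc1nc(Nc2cccc(S(C)(=O)=O)c2)c2sc(-c3ccc(C(F)(F)F)cc3)cc2n1` differs from compound 1 by 3-(methylsulfonyl)phenyl in place of 2-(piperazin-1-yl)ethyl on a nitrogen on an aromatic ring. For the measured compounds named here, that change resembles the one to compound 2, so a modest drop of about the same size is expected, as a 3.1-fold lower number from compound 1 to compound 3 (0.49 log units; beyond the scatter). Compound 3 is therefore estimated at 65 ug/mL, with a likely range from 25 ug/mL to 160 ug/mL.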

Compound 3, solubility: < 5 ug/mL
Compound 3 ended at the assay's limit (the forecaster's own chance of this, stated with the estimate: 5%); at least 13-fold (1.11 log units) between middle value and limit.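

Swapping the group on the aromatic ring turned out to matter far more than compound 2 alone suggested: methylsulfonyl in place of carbamoyl on an aromatic carbon gives an at least 17-fold lower number from compound 2 to compound 3 (1.23 log units; beyond the scatter). The whole change at this nitrogen gives an at least 40-fold lower number from compound 1 to compound 3 (1.60 log units; beyond the scatter), so an aryl ring here does not fix the outcome, since the group it carries can shift it strongly. In this assay, compound 3 stands at a limit and not at a number: the limit of < 5 ug/mL in this assay, at which 1 of the 3 values shown sits.

Going by these compounds, how far compound 3 lies past that limit remains open. So does whether a phenyl ring carrying an amine or a carboxylic acid would stay nearer to compound 1.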